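Pyrazole series: chloro for trifluoromethyl and kinetic solubility

A few compounds are considered here, and "the series" means these few. Any claim that something is new, unique, unknown or untested is made for them only; others in the source may bear on it.

Three compounds of the series have been run in a physicochemical assay for solubility, read by HPLC, in phosphate buffer, measured as kinetic solubility, at pH 7.4; a lower number here means a less soluble compound, a higher number a more soluble compound. Compound 1 `CCC(=O)c1cc(-c2ccc(S(N)(=O)=O)cc2)n(-c2ccc(Cl)cc2)n1` gives 41900 nM in this assay. Compound 2 `CCC(=O)c1cc(-c2ccc(S(N)(=O)=O)cc2)n(-c2ccc(C(F)(F)F)cc2)n1` gives 7500 nM. The two differ in one place, (chloro in place of trifluoromethyl on an aromatic carbon), and the step of a 5.6-fold higher number from compound 2 to compound 1 (0.75 log units; beyond the scatter). Compound 3 `CCC(=O)c1cc(-c2ccc(S(N)(=O)=O)cc2)n(-c2ccc(C(F)(F)F)cn2)n1` gives 99400 nM, the highest of the three numbers; how its core differs from that of compound 2 is not broken down here.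

Compound 4 `CCC(=O)c1cc(-c2ccc(S(N)(=O)=O)cc2)n(-c2ccc(Cl)cn2)n1` is not yet measured. It differs from compound 3 by chloro in place of trifluoromethyl on an aromatic carbon. Among the measured compounds shown here, this is the same kind of change as the one from compound 2 to compound 1, but not the same: there the place was a six-membered aromatic ring of carbon only, here it is a six-membered aromatic ring with 1 nitrogen, two atoms from the ring nitrogen, in both cases para to a large group. For the measured compounds named here, the step for compound 4 is expected to be a 3.0-fold higher number from compound 3 to compound 4 (0.48 log units; beyond the scatter), resting on the single earlier step of a 5.6-fold higher number from compound 2 to compound 1 (0.75 log units; beyond the scatter). Compound 4 is estimated at 300000 nM, between 110000 nM and 800000 nM.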

Compound 4, solubility: 33700 nM
Compound 4: middle estimate off by 8.9-fold (0.95 log units), on the high side; the whole stated range lies above it.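

In this assay chloro in place of trifluoromethyl on an aromatic carbon gives a 2.9-fold lower number from compound 3 to compound 4 (0.47 log units; beyond the scatter) on the core of compound 3, while the same change gave a 5.6-fold higher number from compound 2 to compound 1 (0.75 log units; beyond the scatter) on the core of compound 2, so the direction of this step did not carry from one core to the other. The step of a 1.2-fold lower number from compound 1 to compound 4 (0.09 log units; within the scatter) lies within the scatter, so the two chloro compounds cannot be told apart by this read-out, 5-chloropyridin-2-yl in place of 4-chlorophenyl on an aromatic nitrogen notwithstanding. Two steps on two cores show that the result of this change depends on the core in this small set, but they give no general rule, and nothing at hand explains the opposite directions.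

On these data alone, whether a nitrile, a methoxy group or an amine at the same place would follow the chloro or the trifluoromethyl compounds remains open. Also open, as far as these compounds go, is how this change behaves on any further core, or with a longer chain in place of the propanoyl group.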